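Benzofuran in place of indole on the benzylic group

The source may report more compounds than this note shows. Statements on the series, on what has been measured and on what is new or still open speak of the compounds shown alone.

Compound 2 `CNC(=O)c1cc(C(=O)NC2CC2)cn(Cc2cccc3[nH]ccc23)c1=O` gives 2.9 in a physicochemical assay for lipophilicity, at pH 7.4 (a lower number here means a more polar compound, a higher number a more lipophilic compound), and stands lowest of the two numbers in hand. Compound 1 `CNC(=O)c1cc(C(=O)NCC(C)C)cn(Cc2ccccc2)c1=O` gives 4.3 in this assay, a number that lies higher than that of compound 2 by more than the scatter; the two compounds differ in more than one place, so the gap is read only as what the two values show. Compound 3 `CNC(=O)c1cc(C(=O)NC2CC2)cn(Cc2cccc3occc23)c1=O` has not yet been measured in this assay. The change from compound 2 to compound 3 is 1-benzofuran-4-yl in place of 1H-indol-4-yl on a saturated chain carbon bound to an aromatic nitrogen. Going by the values given here, no measured pair tracks that exact change, so the expected step of a number 0.50 log units higher from compound 2 to compound 3 (beyond the scatter) is a moderate rise, likely just beyond the scatter rather than a large jump. Compound 3 is estimated at 3.4, with a range from 3 to 3.9.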

Compound 3, distribution coefficient: 3.4
Compound 3: the middle estimate sits on the measured number at the digits printed; low and high end bracket the measured number.
By their numbers in this assay, from the lowest: compound 2; then compound 3; then compound 1.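

In this assay, going by these compounds alone, the exchange of 1H-indol-4-yl for 1-benzofuran-4-yl on a saturated chain carbon bound to an aromatic nitrogen gives a number 0.50 log units higher from compound 2 to compound 3 (beyond the scatter) and is the first step that can be read at a single place. The exchange removes the hydrogen-bond donor of the indole and brings in a hydrogen-bond acceptor with ring sizes unchanged, so the modest step belongs to this one change and not to the several differences that separate compound 1 from the others. Nothing at hand gives a reason for the size of this step.

Compound 1 still differs from compound 2 and compound 3 in more than one place, so its value cannot be tied to this position. Also open, from the compounds shown here alone, is how far the number moves at this place with a group carrying an amine or a carboxylic acid, since both groups compared here have no net charge.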